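Adding a Trifluoromethyl Group to the Phenyl of Compound 3

The compounds below may be only part of what the source reports. "The series", "measured", "known", "first", "only" and "open" are said of these compounds alone.

Measured so far in an assay on isolated protein for agonist activity at Free fatty acid receptor 1 (Homo sapiens); on this read-out lower numbers stand for an effect already at smaller amounts and higher numbers for an effect only at larger amounts of compound:
compound 1, `CC#CC(CC(=O)O)c1ccc(OCc2ccc3nc(-c4ccc(F)cc4F)cn3c2)cc1`: 825 nM
compound 2, `CC#CC(CC(=O)O)c1ccc(OCc2ccc3nc(-c4ccc(C5CCCCC5)cc4)cn3c2)cc1`: 417 nM
compound 3, `CC#CC(CC(=O)O)c1ccc(OCc2ccn3cc(-c4ccccc4)nc3c2)cc1`: 1260 nM

Compound 3 carries the highest number of the three. Its nearest neighbour is compound 1, whose number is lower by an amount that stays within the scatter, so the two cannot be told apart; compound 2 is furthest away, lower by an amount beyond the scatter. For the measured compounds named here, compound 3 and compound 2 also differ in how their shared core is joined, so no single step links them.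

Compound 4 `CC#CC(CC(=O)O)c1ccc(OCc2ccn3cc(-c4ccc(C(F)(F)F)cc4)nc3c2)cc1` follows from compound 3 by trifluoromethyl in place of hydrogen on an aromatic carbon. Going by the values given here, the only measured step that speaks to substitution of this pendant phenyl is a 2.0-fold lower number from compound 1 to compound 2 (0.30 log units; within the scatter), and it lies within the scatter. That step exchanges one substituted phenyl for another in a differently joined core, so it bears on the present change only loosely. Among the compounds with values here, with that as the sole guide, the expected step in this assay from compound 3 to compound 4 is a 1.8-fold lower number from compound 3 to compound 4 (0.26 log units; within the scatter), toward a lower number but not clearly beyond the scatter. Compound 4 is therefore estimated at 700 nM, with a range from 300 nM to 1600 nM.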

Compound 4, half-maximal effective concentration: 674 nM
Beside the measured number, compound 4's estimate is 1.0-fold (0.02 log units) above it, and the stated range covers the measured number.
By their numbers in this assay, from the lowest: compounds 2, 4, 1 and 3 (each within the scatter of the next, the first and the last beyond it).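

In this assay, a 1.9-fold lower number from compound 3 to compound 4 (0.27 log units; within the scatter) is the first step shown on the core of compound 3, and the first in which a group replaces hydrogen on this phenyl instead of one substituted phenyl replacing another. It shows that trifluoromethyl on this aromatic carbon, para to a large group, gives a number that cannot be told apart from that of compound 3, so this single change does not separate the two compounds on this read-out. No evidence bears on this result, and the numbers alone give no account of it.

The compounds shown leave open whether a different group at this carbon, such as an amine, a carboxylic acid or a longer chain, would move the number beyond the scatter of compound 3. They also leave open whether trifluoromethyl elsewhere on this phenyl, or on the same phenyl in the differently joined core of compounds 1 and 2, would give a step of similar size.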